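Leaving 2,4-dichlorophenyl for 1,3-thiazol-2-yl

This account rests on a few compounds, and the source may have more. Where it says the series, first, only, none or still open, it means among the compounds named here.

Measured in a functional assay on A549 cells (Homo sapiens) for inhibition, read by MTT assay, with a stated time of 48 h; a higher number here means a weaker inhibitor, a lower number a stronger inhibitor:
compound 1 `Cc1ccc(NC(=O)Nc2cccc(-c3cccc4[nH]nc(N)c34)c2)cc1`: 1660 nM
compound 2 `Nc1n[nH]c2cccc(-c3cccc(NC(=O)Nc4ccc(F)c(F)c4)c3)c12`: 3040 nM
compound 3 `Nc1n[nH]c2cccc(-c3cccc(NC(=O)Nc4ccc(Cl)cc4Cl)c3)c12`: > 500000 nM (a limit, not a number)

Compound 3 gives no true number, only (the limit of > 500000 nM in this assay, at which 1 of the 3 values shown sits), and its steps mark it as the weakest of the three. Compound 4 `Nc1n[nH]c2cccc(-c3cccc(NC(=O)Nc4nccs4)c3)c12` carries 1,3-thiazol-2-yl in place of 2,4-dichlorophenyl on an amide-type nitrogen.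

Two large steps bear on this: an at least 300-fold higher number from compound 1 to compound 3 (2.47 log units; beyond the scatter) and an at least 160-fold higher number from compound 2 to compound 3 (2.21 log units; beyond the scatter). By contrast, a 1.8-fold higher number from compound 1 to compound 2 (0.26 log units; within the scatter) stays within the scatter. Losing 2,4-dichlorophenyl is therefore expected to bring a large drop toward compound 1 and compound 2, although no 1,3-thiazol-2-yl compound has been measured, so the range is wide. The expected change is an at least 83-fold lower number from compound 3 to compound 4 (1.92 log units; beyond the scatter). For compound 4 the estimate is 6000 nM, with an expected range from 1000 nM to 60000 nM.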

Compound 4, half-maximal inhibitory concentration: > 500000 nM
Compound 4 was reported as a limit; the forecaster's own chance of this, stated with the estimate: 15%; middle value at least 83-fold (1.92 log units) away from the limit.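

Leaving 2,4-dichlorophenyl is therefore not enough to recover the activity of compound 1 and compound 2: with 1,3-thiazol-2-yl on the amide-type nitrogen, the result is an at least 300-fold higher number from compound 1 to compound 4 (2.47 log units; beyond the scatter) and an at least 160-fold higher number from compound 2 to compound 4 (2.21 log units; beyond the scatter). The step between compound 3 and compound 4 cannot be read, as both values are limits and not numbers. Two quite different groups at this position now end at the same ceiling: the limit of > 500000 nM in this assay, at which 2 of the 4 values shown sit.

As far as these compounds go, how weak compound 3 and compound 4 truly are remains open. So does whether an unsubstituted phenyl or a pyridin-2-yl group here would give a readable number.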